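Pyrazole series: ring size on the aminomethyl side chain

The source may hold more compounds than are shown below. What is called first, only, known or untested is meant among the compounds shown, and "the series" means these compounds.

Working notes on the aminomethyl series sharing the core of compound 1 `Oc1ccc(CNc2cc(C(F)(F)F)cc3[nH]ncc23)cc1`. In an assay for inhibition of Tryptophan 2,3-dioxygenase (Homo sapiens), with stated times of 10 min and 60 min (on this read-out lower numbers stand for stronger inhibition and higher numbers for weaker inhibition), compound 1 gives 2550 nM. Compound 2 `FC(F)(F)c1cc(NC[C@H]2CCCN2)c2cn[nH]c2c1` gives 6090 nM in this assay, a step of a 2.4-fold higher number from compound 1 to compound 2 (0.38 log units; beyond the scatter). Compound 3 `FC(F)(F)c1cc(NCC2CNC2)c2cn[nH]c2c1` reaches only a limit in this assay, > 100000 nM, so no number stands for it; it sits at the limit of the limit of > 100000 nM in this assay, at which 1 of the 3 values shown sits. The steps into compound 3 are an at least 39-fold higher number from compound 1 to compound 3 (1.59 log units; beyond the scatter) and an at least 16-fold higher number from compound 2 to compound 3 (1.21 log units; beyond the scatter).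

Compound 4 `FC(F)(F)c1cc(NC[C@@H]2CCCCN2)c2cn[nH]c2c1` is not yet measured. Its change from compound 3 is piperidin-2-yl in place of azetidin-3-yl on a saturated chain carbon bound to a nitrogen on an aromatic ring. The step of an at least 16-fold higher number from compound 2 to compound 3 (1.21 log units; beyond the scatter) bears most directly: pyrrolidin-2-yl and piperidin-2-yl share the point of attachment on the ring, and the move to azetidin-3-yl cost a large step. Reversing that in this assay, compound 4 is expected to give a large step back downward, an at least 12-fold lower number from compound 3 to compound 4 (1.09 log units; beyond the scatter), landing near compound 2. The estimate for compound 4 in this assay is 8000 nM, with a range of 2500 nM to 30000 nM.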

Compound 4, half-maximal inhibitory concentration: 8050 nM
Compound 4: the middle estimate sits 1.0-fold (0.00 log units) below what was measured; low and high end bracket the measured number.
By their numbers in this assay, from the lowest: compound 1; then compounds 2 and 4 (each within the scatter of the next). At a limit, above all of these: compound 3.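

In this assay, piperidin-2-yl and pyrrolidin-2-yl on the saturated chain carbon are not told apart, with a 1.3-fold higher number from compound 2 to compound 4 (0.12 log units; within the scatter) as the step, so compound 4 adds a second ring at this position that retains measurable inhibition. The 4-hydroxyphenyl group still keeps an edge over the new ring, with a 3.2-fold higher number from compound 1 to compound 4 (0.50 log units; beyond the scatter) as the modest step, as it does over pyrrolidin-2-yl in compound 2. Compound 3 stands at a limit and not at a number, so an at least 12-fold lower number from compound 3 to compound 4 (1.09 log units; beyond the scatter) gives only the minimum size of this step: the limit of > 100000 nM in this assay, at which 1 of the 4 values shown sits.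

Azetidin-3-yl differs from piperidin-2-yl in both ring size and point of attachment, and the compounds shown do not separate the two. An azetidin-2-yl or a piperidin-3-yl group would address that question.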